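Swapping a Fluorinated Benzyl for a Chlorinated One

This account rests on a few compounds, and the source may have more. Where it says the series, first, only, none or still open, it means among the compounds named here.

Compound 1 `O=C1/C(=C/c2ccccc2F)CN(Cc2cn(Cc3ccc(F)cc3)nn2)C/C1=C\c1ccccc1F` is the reference point. Going by the values given here, in a functional assay on DU-145 cells (Homo sapiens) for cytotoxicity, read by MTT assay, with a stated time of 24 h (a higher number here means a weaker inhibitor, a lower number a stronger inhibitor), compound 1 gives 8700 nM, the only measured number in this small set. Compound 2 `COc1ccc(/C=C2\CN(C(=S)SCc3cn(Cc4ccccc4Cl)nn3)C/C(=C\c3ccc(OC)cc3)C2=O)cc1` returns only a limit of the assay in this assay, namely > 80000 nM. That result is the limit of > 80000 nM in this assay, at which 1 of the 2 values shown sits. Compound 3 `O=C1/C(=C/c2ccccc2F)CN(Cc2cn(Cc3ccccc3Cl)nn2)C/C1=C\c1ccccc1F` has not yet been measured; it differs from compound 1 by a single change, (2-chlorophenyl in place of 4-fluorophenyl on a saturated chain carbon bound to an aromatic nitrogen). Among the compounds with values here, no step between two measured compounds is recorded, so there is no measured change of this kind to lean on. A swap of one benzyl group for another of similar size is expected to move this assay little, if at all, beyond the usual scatter, and the expected step is a 1.1-fold lower number from compound 1 to compound 3 (0.04 log units; within the scatter). Compound 3 is therefore estimated at 8000 nM, with a plausible range from 3000 nM to 25000 nM.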

Compound 3, half-maximal inhibitory concentration: 7500 nM
Estimate against measurement, compound 3: 1.1-fold (0.03 log units) above; low and high end bracket the measured number.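

Replacing 4-fluorophenyl with 2-chlorophenyl on a saturated chain carbon bound to an aromatic nitrogen gives a 1.2-fold lower number from compound 1 to compound 3 (0.06 log units; within the scatter) in this assay. Going by these compounds alone, this is the first measured step at this position, and it shows that the two compounds cannot be told apart here, even though the halogen and its ring position differ in a single swap. For this pair, then, the position accepts one halogen-bearing benzyl group in place of the other, and nothing measured here gives a reason for that result.

Going by these compounds, the fluorine and the chlorine were exchanged together with their ring positions, so the effect of each change alone stays open. Also open, on these data alone, is whether this position would tolerate a group of a different kind, such as a benzyl carrying an amine or a carboxylic acid, or a longer alkyl chain in place of the benzyl.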